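Removing the aromatic ethyl from compound 3

The compounds below may be only part of what the source reports. "The series", "measured", "known", "first", "only" and "open" are said of these compounds alone.

Measured so far in a functional assay on the whole organism with Rattus norvegicus as the target; on this read-out higher numbers stand for an effect only at larger amounts of compound and lower numbers for an effect already at smaller amounts:
compound 1 `CCCCc1c(OC)nc2nc(C(=O)c3ccccc3)cn2c1CC` gives 10 mg/kg
compound 2 `C=CCc1c(OC)nc2nc(C(=O)c3ccccc3)cn2c1CC` gives 10 mg/kg
compound 3 `CCc1c(OC)nc2nc(C(=O)c3ccccc3)cn2c1CC` gives 2 mg/kg

Compound 3 holds the lowest number of the three; the step of a 5.0-fold lower number from compound 1 to compound 3 (0.70 log units; beyond the scatter) and the step of a 5.0-fold lower number from compound 2 to compound 3 (0.70 log units; beyond the scatter) both lie beyond the scatter, while no change at the digits printed from compound 1 to compound 2 (within the scatter) stays within it. Compound 4 `CCc1cc(OC)nc2nc(C(=O)c3ccccc3)cn12` differs from compound 3 by hydrogen in place of ethyl on an aromatic carbon, a change on an aromatic carbon of the core. Within the data shown here, none of the measured steps touches that position; all three alter the saturated chain bound to an aromatic carbon. The shortening steps a 5.0-fold lower number from compound 1 to compound 3 (0.70 log units; beyond the scatter) and a 5.0-fold lower number from compound 2 to compound 3 (0.70 log units; beyond the scatter) gave modest lower numbers, but they do not bear directly on an aromatic ethyl. For compound 4 the expected step is a 1.5-fold higher number from compound 3 to compound 4 (0.18 log units; within the scatter), and the estimated value is 3 mg/kg, in the range 1 mg/kg to 10 mg/kg.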

Compound 4, minimum effective dose: 2 mg/kg
Compound 4: middle estimate off by 1.5-fold (0.18 log units), on the high side; low and high end bracket the measured number.
By their numbers in this assay, from the lowest: compounds 3 and 4 (each within the scatter of the next); then compounds 1 and 2 (each within the scatter of the next).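

In this assay, the aromatic carbon ortho to a methoxy group tolerates loss of its ethyl, with no change at the digits printed from compound 3 to compound 4 (within the scatter) as the step. Hydrogen there also compares with the larger groups, with a 5.0-fold lower number from compound 2 to compound 4 (0.70 log units; beyond the scatter) on losing allyl and a 5.0-fold lower number from compound 1 to compound 4 (0.70 log units; beyond the scatter) on losing butyl, so among these four compounds hydrogen and ethyl sit together, apart from allyl and butyl. Nothing available gives a reason for these steps. From the compounds shown here alone, whether an amine, a carboxylic acid or a chlorine on this carbon would sit with hydrogen and ethyl or with allyl and butyl stays open. Also open, going by these compounds, is what replacing the methoxy group in compound 4 would do.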